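Swapping the amide aryl group in a cytotoxicity series

The compounds below may be only part of what the source reports. "The series", "measured", "known", "first", "only" and "open" are said of these compounds alone.

Compound 1, with structure `COc1ccc(NC(=O)c2cccc(/C=C3\CC(=O)N(c4ccccc4)C3=O)c2)c(C)c1`, was tested in an ADME assay on HCT-116 cells (Homo sapiens) for cytotoxicity, read by MTT assay, with a stated time of 72 h; a higher number here means a weaker inhibitor, a lower number a stronger inhibitor. In this assay compound 1 reached only the limit of the measurement, giving > 100000 nM, which is not a number but the edge of what the test could report. Compound 2, with structure `COc1ccc(NC(=O)c2cccc(CC3CC(=O)N(c4ccc(C)cc4)C3=O)c2)cc1`, is a related member of the series. In this assay compound 2 likewise stopped at the limit, giving > 100000 nM. Both results sit at the same boundary, as summarised by the limit of > 100000 nM in this assay, at which 2 of the 2 values shown sit, so neither compound showed measurable cell killing.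

Compound 3, with structure `O=C(Nc1cccc(F)c1)c1cccc(/C=C2\CC(=O)N(c3ccccc3)C2=O)c1`, has not yet been measured. It differs from compound 1 in one place: 3-fluorophenyl in place of 4-methoxy-2-methylphenyl on an amide-type nitrogen. For the measured compounds named here, with no measured step to guide it, the expected change from compound 1 is none beyond the scatter, a number no higher from compound 1 to compound 3 (the limit leaves the size open). Compound 3 is therefore estimated to give 100000 nM, somewhere between 30000 nM and 300000 nM.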

Compound 3, half-maximal inhibitory concentration: > 100000 nM
Compound 3 gave a limit, no number; the forecaster's own chance of this, stated with the estimate: 80%; the middle value lies on the limit itself.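

In this assay, for the compounds shown here, compound 1 and compound 3 both stop at a limit of the measurement, so no step between them can be read. The compounds shown leave open whether any amide aryl group on the shared core gives measurable cell killing.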